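Swapping the amide aryl group for a chlorophenyl

The source may hold more compounds than are shown below. What is called first, only, known or untested is meant among the compounds shown, and "the series" means these compounds.

Compound 1 `Cc1cccc(NC(=O)c2ccc(/N=N\c3c[nH]c4ccccc34)cc2)c1C` stands second highest of three numbers in a functional assay on HCT-116 cells (Homo sapiens) for inhibition, read by MTT assay, with a stated time of 72 h (a higher number here means a weaker inhibitor, a lower number a stronger inhibitor), where compound 1 gives 272000 nM. Its nearest neighbour is compound 3 `Cc1ccccc1NC(=O)c1ccc(/N=N\c2c[nH]c3ccccc23)cc1`, which gives 509000 nM; that step is a 1.9-fold higher number from compound 1 to compound 3 (0.27 log units; within the scatter). Furthest away is compound 2 `COc1ccccc1NC(=O)c1ccc(/N=N\c2c[nH]c3ccccc23)cc1`, which gives 122000 nM; that step is a 2.2-fold lower number from compound 1 to compound 2 (0.35 log units; beyond the scatter). Compound 4 `O=C(Nc1ccc(Cl)cc1)c1ccc(/N=N\c2c[nH]c3ccccc23)cc1` differs from compound 1 in one place: 4-chlorophenyl in place of 2,3-dimethylphenyl on an amide-type nitrogen. Among the measured compounds shown here, no measured step makes exactly this swap. The exchange of the whole aryl group in a 2.2-fold lower number from compound 1 to compound 2 (0.35 log units; beyond the scatter) and the single-group exchange in a 4.2-fold higher number from compound 2 to compound 3 (0.62 log units; beyond the scatter) were both modest, so at most a modest step is expected here, with its direction uncertain. Compound 4 is therefore estimated at 250000 nM, within 80000 nM to 800000 nM. The expected step is a 1.1-fold lower number from compound 1 to compound 4 (0.04 log units; within the scatter).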

Compound 4, half-maximal inhibitory concentration: 187000 nM
Compound 4: the middle estimate sits 1.3-fold (0.13 log units) above what was measured; the range from low to high includes it.
By their numbers in this assay, from the lowest: compounds 2, 4, 1 and 3 (each within the scatter of the next, the first and the last beyond it).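

On this amide-type nitrogen, a ring carrying chlorine can stand in for the earlier rings: 4-chlorophenyl cannot be told apart from 2,3-dimethylphenyl (a 1.5-fold lower number from compound 1 to compound 4 (0.16 log units; within the scatter)) or from 2-methoxyphenyl (a 1.5-fold higher number from compound 2 to compound 4 (0.19 log units; within the scatter)). Only 2-methylphenyl separates from it (a 2.7-fold lower number from compound 3 to compound 4 (0.43 log units; beyond the scatter)), so the gain is limited to that one comparison. Nothing available explains any of these steps.

Still open, as far as these compounds go, is how an unsubstituted phenyl would compare. Also open, from the compounds shown here alone, is whether an amine or a carboxylic acid on this ring would give a larger step.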